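Chloro to Methyl on the Phenylamino Group

The source may hold more compounds than are shown below. What is called first, only, known or untested is meant among the compounds shown, and "the series" means these compounds.

Measured compounds:
compound 1 `C=CC(=O)Nc1cccc(NC(=O)CSc2nc(Nc3ccccc3)c3ccccc3n2)c1`: 7310 nM
compound 2 `C=CC(=O)Nc1cccc(NC(=O)CSc2nc(Nc3ccccc3Cl)c3ccccc3n2)c1`: 20700 nM

In a functional assay on MGC-803 cells (Homo sapiens) for inhibition, read by MTT assay, with a stated time of 72 h (on this read-out higher numbers stand for weaker inhibition and lower numbers for stronger inhibition), compound 2 stands highest of the two numbers; its nearest neighbour, compound 1, gives 7310 nM, a gap beyond the scatter. Compound 3 `C=CC(=O)Nc1cccc(NC(=O)CSc2nc(Nc3ccccc3C)c3ccccc3n2)c1` differs from compound 2 by methyl in place of chloro on an aromatic carbon. Among the measured compounds shown here, the only measured step that touches this position is a 2.8-fold higher number from compound 1 to compound 2 (0.45 log units; beyond the scatter), which shows that a chloro here weakens inhibition modestly. For the measured compounds named here, no measured step compares methyl with chloro, so the expected step is small: a 1.4-fold lower number from compound 2 to compound 3 (0.14 log units; within the scatter). Compound 3 is expected to give about 15000 nM, within 6000 nM to 40000 nM.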

Compound 3, half-maximal inhibitory concentration: 30200 nM
For compound 3 the middle estimate is 2.0-fold (0.30 log units) below the measured one, and the stated range covers the measured number.
By their numbers in this assay, from the lowest: compound 1; then compounds 2 and 3 (each within the scatter of the next).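

With a 1.5-fold higher number from compound 2 to compound 3 (0.16 log units; within the scatter) in this assay chloro and methyl on this aromatic carbon cannot be told apart. Methyl, like chloro, gives weaker inhibition than hydrogen, with a 4.1-fold higher number from compound 1 to compound 3 (0.62 log units; beyond the scatter) as its step, so two different groups at this position both fall short of plain hydrogen. No measured evidence bears on the reason for this. Still open, going by these compounds, is whether any group here can match or beat hydrogen, such as fluoro, methoxy, an amine or a carboxylic acid.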